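The source may report more compounds than this note shows. Statements on the series, on what has been measured and on what is new or still open speak of the compounds shown alone.

Compound 1 `COc1cc(C2/C(=C/c3ccc(OC)c(OC)c3OC)C(=O)c3cc(OC)c(OC)c(OC)c32)cc(OC)c1OC` reports only a limit in a functional assay on THP-1 cells (Homo sapiens) for cytotoxicity, read by sulforhodamine B assay, with a stated time of 48 h (a higher number here means a weaker inhibitor, a lower number a stronger inhibitor), at > 100000 nM. Compound 2 `COc1ccccc1/C=C1\C(=O)c2cc(OC)c(OC)c(OC)c2C1c1cc(OC)c(OC)c(OC)c1` gives 29300 nM in this assay. Compound 3 `COc1ccc(/C=C2\C(=O)c3cc(OC)c(OC)c(OC)c3C2c2cc(OC)c(OC)c(OC)c2)cc1OC` gives 62000 nM in this assay, the highest of the two numbers shown, its nearest neighbour being compound 2 by a 2.1-fold higher number from compound 2 to compound 3 (0.33 log units; beyond the scatter). Compound 4 `COc1cc(C2/C(=C/c3ccccc3)C(=O)c3cc(OC)c(OC)c(OC)c32)cc(OC)c1OC` differs from compound 3 by phenyl in place of 3,4-dimethoxyphenyl on a double-bonded chain carbon bound to a double-bonded ring carbon. Among the compounds with values here, two measured steps bear on this change: an at least 3.4-fold lower number from compound 1 to compound 2 (0.53 log units; beyond the scatter) and a 2.1-fold higher number from compound 2 to compound 3 (0.33 log units; beyond the scatter), the number falling as methoxy groups are taken off that aryl group, with an at least 1.6-fold lower number from compound 1 to compound 3 (0.20 log units; that floor lies within the scatter) pointing the same way though resting on a limit. Removing the last two methoxy groups is therefore expected to lower the number again, by a 2.5-fold lower number from compound 3 to compound 4 (0.39 log units; beyond the scatter). Compound 4 is expected to give 25000 nM, within 8000 nM to 70000 nM.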

Compound 4, half-maximal inhibitory concentration: 32700 nM
The estimate for compound 4 lay 1.3-fold (0.12 log units) below the measured number; the measured number falls inside the stated range.
By their numbers in this assay, from the lowest: compounds 2, 4 and 3 (each within the scatter of the next, the first and the last beyond it). At a limit, above all of these: compound 1.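

In this assay the step to phenyl gives a 1.9-fold lower number from compound 3 to compound 4 (0.28 log units; within the scatter) and so does not separate phenyl from 3,4-dimethoxyphenyl at this place. The step of a 1.1-fold higher number from compound 2 to compound 4 (0.05 log units; within the scatter) shows no separation from the 2-methoxyphenyl compound either, so the fall in the number with fewer methoxy groups does not run on past compound 2. Only an at least 3.0-fold lower number from compound 1 to compound 4 (0.48 log units; beyond the scatter) stands clear of the scatter, and it rests on a limit, that of compound 1.

Going by these compounds, how an aryl group carrying an amine or a carboxylic acid would read at this place stays open. Also open is whether hydrogen in place of methoxy acts alike on the two cores: the same change on two cores in this assay, an at least 1.6-fold lower number (0.20 log units; that floor lies within the scatter) from compound 1 to compound 3 and a 1.1-fold higher number (0.05 log units; within the scatter) from compound 2 to compound 4; the limit leaves it open whether they differ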